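The source may hold more compounds than are shown below. What is called first, only, known or untested is meant among the compounds shown, and "the series" means these compounds.

Compound 1 `Clc1[nH]ccc2ncnc1-2`: > 9 mg/kg
Compound 2 `OC[C@H]1OC(n2cnc3c(Nc4ccccc4)nccc32)[C@H](O)[C@@H]1O`: > 9 mg/kg

In a functional assay on the whole organism (Pleural cavity) with Rattus norvegicus as the target (a higher number here means that more compound is needed for the effect, a lower number that less compound is needed), compound 2 gives > 9 mg/kg, which is a limit of the assay rather than a number. Compound 1 also shows a limit here, > 9 mg/kg. On these data alone, compound 2 thus stands at the limit of > 9 mg/kg in this assay, at which 2 of the 2 values shown sit, so its true dose is unknown. Compound 3 `OC[C@H]1OC(n2cnc3c(S)nccc32)[C@H](O)[C@@H]1O` has not been measured; it differs from compound 2 by sulfanyl in place of anilino on an aromatic carbon. Among the measured compounds shown here, no step between compounds differing in one place has been measured, so there is nothing to build on. I expect the step that the limit leaves unreadable from compound 2 to compound 3 to stay within the scatter. Compound 3 is estimated at 15 mg/kg, between 5 mg/kg and 45 mg/kg.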

Compound 3, dose for half-maximal effect: 9 mg/kg
Beside the measured number, compound 3's estimate is 1.7-fold (0.22 log units) above it, within the range that was stated.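

In this assay, among the compounds shown here, compound 3 gives 9 mg/kg, the first true number in this set. Compound 2 shows only a limit of the assay, > 9 mg/kg. Sulfanyl in place of anilino on this aromatic carbon gives a number no higher from compound 2 to compound 3 (the limit leaves the size open). The size of the step cannot be read because of that limit: the limit of > 9 mg/kg in this assay, at which 2 of the 3 values shown sit.

Open, on these data alone, is how an amine or a longer sulfur-linked chain would fare at this position. Also open, as far as these compounds go, is whether any group here would bring the dose lower than sulfanyl does.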